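The source may hold more compounds than are shown below. What is called first, only, known or untested is meant among the compounds shown, and "the series" means these compounds.

Measured compounds in a functional assay on K562 cells (Homo sapiens) for antiproliferative activity, read by MTT assay, with a stated time of 72 h; a lower number here means a stronger inhibitor, a higher number a weaker inhibitor:
Compound 1 `O=C1NC(=O)/C(=C/C2=Cc3ccccc3OC2)S1` gives 98900 nM.
Compound 2 `CN1C(=O)S/C(=C\C2=Cc3ccccc3OC2)C1=O` gives only a limit, > 100000 nM.

Among the measured compounds shown here, compound 1 holds the only numerical value in this assay; the other entry is a limit, (the limit of > 100000 nM in this assay, at which 1 of the 2 values shown sits). The step of a number no lower from compound 1 to compound 2 (the limit leaves the size open) runs into that limit, so its size cannot be read. Compound 3 `O=C1NC(=O)/C(=C/C2=Cc3cc(Br)ccc3OC2)S1` differs from compound 1 by bromo in place of hydrogen on an aromatic carbon. No measured step touches this change; the single step shown concerns methyl in place of hydrogen on an amide-type nitrogen in a ring and gives no size. The expectation for compound 3 is therefore a step of a 1.6-fold lower number from compound 1 to compound 3 (0.22 log units; within the scatter) that stays near compound 1. Compound 3 is estimated at 60000 nM, range 15000 nM to 200000 nM.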

Compound 3, half-maximal inhibitory concentration: 49800 nM
Beside the measured number, compound 3's estimate is 1.2-fold (0.08 log units) above it, and the stated range covers the measured number.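

In this assay, among the compounds shown here, bromo in place of hydrogen on an aromatic carbon gives a 2.0-fold lower number from compound 1 to compound 3 (0.30 log units; within the scatter), the first step with a readable size. This aromatic carbon therefore takes a bromine atom without a change beyond the scatter, whereas the step at the ring nitrogen cannot be read. Nothing given here accounts for this step.

As far as these compounds go, whether an amine or a carboxylic acid on the same aromatic carbon would move the number beyond the scatter remains open. Also open, from the compounds shown here alone, is whether bromo on the other aromatic carbons of that ring gives a similar step.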